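Closing a chain to an azetidine on a benzylic carbon

The source may hold more compounds than are shown below. What is called first, only, known or untested is meant among the compounds shown, and "the series" means these compounds.

Compound 1 `Cc1cc(OCc2cccc(F)c2)ccc1CN1CC[C@H]1C(N)=O` gives 8650 nM in an assay on Sf9 cells for inhibition of Amine oxidase [flavin-containing] A (Homo sapiens), with stated times of 15 min and 60 min; a lower number here means a stronger inhibitor, a higher number a weaker inhibitor. Compound 2 `C[C@H](NCc1ccc(OCc2cccc(F)c2)cc1F)C(N)=O` reaches only the assay limit, > 10000 nM, in this assay; the limit of > 10000 nM in this assay, at which 1 of the 2 values shown sits, tells where that limit sits. Compound 3 `NC(=O)[C@@H]1CCN1Cc1ccc(OCc2cccc(F)c2)cc1F` carries 2-carbamoylazetidin-1-yl in place of (1-carbamoylethyl)amino on a saturated chain carbon bound to an aromatic carbon, which brings in the four-membered ring seen in compound 1. The step from compound 2 to compound 3 is expected to be modest, toward stronger inhibition, and hardly beyond the scatter: an at least 1.2-fold lower number from compound 2 to compound 3 (0.09 log units; that floor lies within the scatter). Compound 3 is therefore estimated at 8000 nM, with a range from 2500 nM to 25000 nM.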

Compound 3, half-maximal inhibitory concentration: 18600 nM
For compound 3 the middle estimate is 2.3-fold (0.37 log units) below the measured one; low and high end bracket the measured number.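

In this assay, compound 2 stands at a limit, so the step to compound 3 cannot be read: the limit of > 10000 nM in this assay, at which 1 of the 3 values shown sits.

With 2-carbamoylazetidin-1-yl held constant, fluoro in place of methyl on an aromatic carbon gives a 2.2-fold higher number from compound 1 to compound 3 (0.33 log units; beyond the scatter). This shows that the aromatic substituent still changes the reading with the four-membered ring in place.

Open, from the compounds shown here alone, is whether the same exchange would move the number with the (1-carbamoylethyl)amino chain. Also open, going by these compounds, is what a pyrrolidine ring in place of the azetidine, or a carboxylic acid in place of the carbamoyl group, would give.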